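Working notes: amide series, change at the aromatic carbon

The source may hold more compounds than are shown below. What is called first, only, known or untested is meant among the compounds shown, and "the series" means these compounds.

Measured so far:
compound 1 `CC1CCN(c2cc(C(F)(F)F)ccc2CNC(=O)C(C)c2ccc(NS(C)(=O)=O)c(F)c2)CC1`: 0.9 nM
compound 2 `Cc1ccc(N2CCN(c3cc(C(F)(F)F)ccc3CNC(=O)C(C)c3ccc(NS(C)(=O)=O)c(F)c3)CC2)cc1`: 0.7 nM

In an assay on CHO cells for antagonist activity at transient receptor potential cation channel subfamily V member 1 (Homo sapiens), read by FLIPR (a higher number here means a weaker inhibitor, a lower number a stronger inhibitor), compound 1 gives 0.9 nM, the higher of the two numbers, though its gap to compound 2 lies within the scatter. Compound 3 `CC(C(=O)NCc1ccc(C(F)(F)F)cc1SCCCO)c1ccc(NS(C)(=O)=O)c(F)c1` differs from compound 1 by (3-hydroxypropyl)sulfanyl in place of 4-methylpiperidin-1-yl on an aromatic carbon, that is, meta to the trifluoromethyl group and ortho to the large group. For the measured compounds named here, no measured pair shows this kind of change, so the step in this assay can only be judged from the structures. The group that enters is smaller and carries a hydrogen-bond donor; a step toward a weaker inhibitor, beyond the scatter, is expected, an 8.9-fold higher number from compound 1 to compound 3 (0.95 log units; beyond the scatter). Compound 3 is estimated at 8 nM, with a range of 2 nM to 40 nM.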

Compound 3, inhibition constant: "not active" (no number reported)
For compound 3 the study gives words and no number; the estimate stays without a comparison.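

For the compounds shown here, compound 3 is reported as not active in this assay, without a number, so no step from compound 1 can be read. No evidence bears on this result. The compounds shown leave open which difference between 4-methylpiperidin-1-yl and (3-hydroxypropyl)sulfanyl goes with this outcome.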